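Swapping a Phenyl for a Pyridinylmethyl on the Ring Nitrogen

The compounds below may be only part of what the source reports. "The series", "measured", "known", "first", "only" and "open" are said of these compounds alone.

Of the compounds shown here, two have been measured so far. Compound 1 `Nc1ccccc1NC(=O)c1ccc(CSC(=S)N2CCN(c3ccccc3)CC2)cc1` and compound 2 `CCN(Cc1ccncc1)C(=S)SCc1ccc(C(=O)Nc2ccccc2N)cc1` share the same core and were both tested in a functional assay on HeLa cells (Homo sapiens) for antiproliferative activity, read by CCK-8 assay, with a stated time of 72 h, tested at 8 uM; a higher number here means a stronger effect of the compound at the concentration tested, a lower number a weaker effect. In this assay compound 1 gives 73.1%, and compound 2 gives 77.7%. Compound 1 has the lower of the two numbers, but the gap to compound 2 is within the usual scatter, so the two compounds read as alike.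

Compound 3 `Nc1ccccc1NC(=O)c1ccc(CSC(=S)N2CCN(Cc3ccncc3)CC2)cc1` differs from compound 1 in a single place: (pyridin-4-yl)methyl in place of phenyl on an amine nitrogen in a ring. Within the data shown here, no step between two measured compounds is available to size this change. Compound 2 does carry the same (pyridin-4-yl)methyl group, though on a different nitrogen, and in this assay compound 2 gives 77.7%, a number close to that of compound 1. On that basis the step of a number 1.9 percentage points higher from compound 1 to compound 3 (within the scatter) is expected to be small, in no clear direction, and not beyond the scatter. Compound 3 is therefore estimated at 75% in this assay, with a likely range from 62% to 87%.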

Compound 3, a percentage reported as inhibition, at one concentration (the size of the read-out at that concentration, not a potency): 72.9%
Compound 3: the middle estimate sits 2.1 percentage points above what was measured, within the range that was stated.
By their numbers in this assay, from the lowest: compounds 3, 1 and 2 (each within the scatter of the next).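

Among these compounds, this is the first direct measure at this position: in this assay putting (pyridin-4-yl)methyl in place of phenyl on the amine nitrogen in the ring gives a number 0.2 percentage points lower from compound 1 to compound 3 (within the scatter) and so leaves the two compounds reading as alike. At this position, then, an aromatic ring of carbon only can give way to an aromatic ring with a hetero atom, together with a hydrogen-bond acceptor that phenyl does not have, with no difference that stands out from the scatter at the one concentration tested. Nothing measured here speaks to why these two groups read alike.

Both groups carry a six-membered aromatic ring, so the compounds shown leave open whether something without such a ring on this nitrogen, such as a plain methyl, a longer alkyl chain or a carboxylic acid, would give a number clearly apart from these. A single-concentration read-out is also not a potency, so compound 1 and compound 3 could still separate in a full dose-response measurement.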